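The compounds below may be only part of what the source reports. "The series", "measured", "known", "first", "only" and "open" are said of these compounds alone.

In a functional assay on the whole organism (strain Wister albino) for inhibition, with Rattus norvegicus as the target, read by paw edema, with stated times of 1 h and 4 h, at a dose of 50 mg/kg by the intraperitoneal route (a lower number here means less inhibition, a higher number more inhibition at the dose given (going by the name of the read-out)), two compounds of a shared core have been examined. Compound 1 `CCOC(=O)c1c(-c2ccc(Cl)cc2)cc(-c2ccccc2)nc1Nc1ccccc1` gives 83.8% in this assay. Compound 2 `CCOC(=O)c1c(-c2ccc(F)cc2)cc(-c2ccccc2)nc1N1CCCCC1` gives 76% in this assay, the lower of the two numbers, though its gap to compound 1 lies within the usual scatter, so no order between them can be read.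

Compound 3 `CCOC(=O)c1c(-c2ccc(F)cc2)cc(-c2ccccc2)nc1Nc1ccccc1` has not yet been measured in this assay. It differs from compound 2 in one place: anilino in place of piperidin-1-yl on an aromatic carbon. For the measured compounds named here, the anilino group is also the one found on the core of compound 1, which sits at the upper of the two known numbers.

Going by the values given here, with only two measured compounds and no step between them in hand, a large move is not expected. The step from compound 2 to compound 3 in this assay is estimated at a number 4 percentage points higher from compound 2 to compound 3 (within the scatter), a small rise that stays within the scatter. Compound 3 is therefore expected to give about 80% in this assay, most likely between 68% and 90%.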

Compound 3, a percentage reported as inhibition, in the whole organism at one dose (the size of the read-out at that dose, not a potency): 76%
For compound 3 the middle estimate is 4 percentage points above the measured one; the range from low to high includes it.
By their numbers in this assay, from the lowest: compounds 2, 3 and 1 (each within the scatter of the next).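

Replacing piperidin-1-yl with anilino on the aromatic carbon next to the ring nitrogen gives in this assay no change at the digits printed from compound 2 to compound 3 (within the scatter), so with the 4-fluorophenyl group in place, this read-out does not separate the non-aromatic ring from the aromatic one at this position. Fluoro in place of chloro on an aromatic carbon, with anilino kept, gives a number 7.8 percentage points lower from compound 1 to compound 3 (within the scatter), so this halogen exchange cannot be told from the scatter either. Nothing at hand gives a cause for either result.

On these data alone, it remains open whether a morpholin-4-yl group or a longer chain ending in an amine at this position, or a carboxylic acid in place of the ethoxycarbonyl group, would move the number beyond the scatter. As far as these compounds go, it is also open how piperidin-1-yl behaves together with chloro, as it appears here only with fluoro.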